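The source may hold more compounds than are shown below. What is called first, only, known or untested is meant among the compounds shown, and "the series" means these compounds.

Compound 1 `Nc1ccccc1NC(=O)c1ccc(CSC(=S)N2CCN(c3ccccc3)CC2)cc1` is the starting point here. In a functional assay on MGC-803 cells (Homo sapiens) for antiproliferative activity, read by CCK-8 assay, with a stated time of 72 h, tested at 2 uM (on this read-out lower numbers stand for a weaker effect and higher numbers for a stronger effect at the one concentration tested), compound 1 gives 42.3%. Compound 2 `Cc1ccc(N2CCN(C(=S)SCc3ccc(C(=O)Nc4ccccc4N)cc3)CC2)cc1` carries a methyl in place of hydrogen on an aromatic carbon, and in this assay compound 2 gives 33.4%. Within the data shown here, the only step measured so far, a number 8.9 percentage points lower from compound 1 to compound 2 (within the scatter), stays within the usual scatter, so on these two numbers compound 2 stands within the scatter of compound 1, and nothing separates the two beyond what repeated measurements would show.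

Compound 3 `Nc1ccccc1NC(=O)c1ccc(CSC(=S)N2CCN(c3ncccn3)CC2)cc1` is the next compound. Relative to compound 2 the change is pyrimidin-2-yl in place of 4-methylphenyl on an amine nitrogen in a ring. Among the measured compounds shown here, the one measured step touches the same aromatic ring on the amine nitrogen in a ring, yet it only swapped methyl for hydrogen and moved nothing beyond the scatter; no measured step covers the exchange of a whole 4-methylphenyl for a pyrimidin-2-yl. With so little to lean on, the step of a number 4.6 percentage points higher from compound 2 to compound 3 (within the scatter) is expected to stay within the scatter, in no clear direction. Compound 3 is therefore estimated at 38%, somewhere between 20% and 58%.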

Compound 3, a percentage reported as inhibition, at one concentration (the size of the read-out at that concentration, not a potency): 28.4%
Estimate against measurement, compound 3: 9.6 percentage points above; measured number inside the range.
By their numbers in this assay, from the lowest: compounds 3, 2 and 1 (each within the scatter of the next, the first and the last beyond it).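

In this assay the substituent on the amine nitrogen in a ring now gives its first step beyond the usual scatter: pyrimidin-2-yl in place of phenyl brings a number 13.9 percentage points lower from compound 1 to compound 3 (beyond the scatter) and this step remains modest. The same ring exchanged for 4-methylphenyl gives a number 5 percentage points lower from compound 2 to compound 3 (within the scatter) so the change can be told apart from repeat-measurement noise only against the unsubstituted phenyl, and compound 2 cannot be separated from either neighbour. The swap also alters two things at once, as the entering ring has 2 nitrogen atoms and 2 hydrogen-bond acceptors and is one heavy atom smaller than 4-methylphenyl, and no measurement here accounts for the lower number.

The compounds shown leave open whether a single ring nitrogen, as in pyridin-2-yl, would sit with phenyl or with pyrimidin-2-yl, and whether a group without an aromatic ring, such as a simple methyl or a benzyl group with its extra carbon, would be tolerated at this amine nitrogen. They also leave open how these differences at one concentration would translate into potency.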